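This account rests on a few compounds, and the source may have more. Where it says the series, first, only, none or still open, it means among the compounds named here.

Working notes on a small series sharing one core. Compound 1 `Cc1c(C(=O)CSCCN)[n+]([O-])c2ccccc2[n+]1[O-]` and compound 2 `Cc1c(C(=O)CSCCO)[n+]([O-])c2ccccc2[n+]1[O-]` carry an aminoethyl and a hydroxyethyl thioether on the side chain; in an ADME assay on Vero cells (Chlorocebus sabaeus) for cytotoxicity, read by MTT assay, with a stated time of 72 h (on this read-out lower numbers stand for higher toxicity in this test and higher numbers for lower toxicity in this test), compound 1 gives "not determined" (no result reported) and compound 2 gives "not determined" (no result reported), so neither contributes a number. Within the data shown here, compound 3 `Cc1c(C(=O)CSc2ccccc2)[n+]([O-])c2ccccc2[n+]1[O-]` carries a phenyl thioether and is the only member with a result: in this assay compound 3 gives 50 ug/mL. Among the measured compounds shown here, it therefore stands alone as the sole reference point; no comparison between measured compounds can be drawn.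

Compound 4 `COc1ccc(SCC(=O)c2c(C)[n+]([O-])c3ccccc3[n+]2[O-])cc1` is not yet measured. It differs from compound 3 in one place: methoxy in place of hydrogen on an aromatic carbon. The shared core, the carbonyl and the thioether link are unchanged; only the aromatic ring at the end of the side chain is altered.

For the measured compounds named here, with a single measured value and no measured step, the expectation rests on the size of the change alone. A methoxy entering on an aromatic carbon is a small alteration, and in this assay the step is expected to stay within the usual scatter, with no direction that can be asserted. The estimated step from compound 3 to compound 4 is no change at the digits printed from compound 3 to compound 4 (within the scatter). Compound 4 is expected to give about 50 ug/mL in this assay, with a range from 25 ug/mL to 100 ug/mL.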

Compound 4, half-maximal cytotoxic concentration: 50 ug/mL
The estimate for compound 4 equals the measured number at the digits printed; the measured number falls inside the stated range.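

this assay now holds its first step between measured compounds, and for phenyl to 4-methoxyphenyl it reads no change at the digits printed from compound 3 to compound 4 (within the scatter) in this series. Compound 3 alone gave a single reference point, whereas this pair shows that methoxy in place of hydrogen, at this place on the aromatic ring at the end of the side chain, para to a large group, does not move the read-out beyond the scatter. This is one substitution at one position on one ring, and no measured data on hand offer an explanation for the result.

The steps involving compound 1 and compound 2 cannot be read, so the aminoethyl and hydroxyethyl thioethers cannot yet be set against the aromatic thioethers. On these data alone, it remains open whether an amine or a carboxylic acid at this same place on the ring, or a longer chain in place of the phenyl, would give a step beyond the scatter.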